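The source may report more compounds than this note shows. Statements on the series, on what has been measured and on what is new or still open speak of the compounds shown alone.

Three compounds share one core and differ only in the acyl group on the amide nitrogen. Compound 1 `C=C(C)C(=O)Nc1cc2c(N3CCc4ccccc43)ncnc2cc1O[C@@H]1CCOC1` carries a 1-methylethenyl group on the carbonyl carbon, and in a functional assay on PC-3 cells (Homo sapiens) for antiproliferative activity, read by MTT assay, with a stated time of 72 h (on this read-out lower numbers stand for stronger inhibition and higher numbers for weaker inhibition), compound 1 gives 4910 nM. Compound 2 `CC(C)=CC(=O)Nc1cc2c(N3CCc4ccccc43)ncnc2cc1O[C@@H]1CCOC1` carries a 2-methylprop-1-en-1-yl group there, and in this assay compound 2 gives 4620 nM. Compound 3 `CCC/C=C/C(=O)Nc1cc2c(N3CCc4ccccc43)ncnc2cc1O[C@@H]1CCOC1` carries a pent-1-en-1-yl group, and in this assay compound 3 gives 9230 nM, the highest of the three numbers, though a 1.9-fold higher number from compound 1 to compound 3 (0.27 log units; within the scatter) and a 2.0-fold higher number from compound 2 to compound 3 (0.30 log units; within the scatter) both stay within the scatter, as does a 1.1-fold lower number from compound 1 to compound 2 (0.03 log units; within the scatter).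

Compound 4 `O=C(/C=C/CN1CCCCC1)Nc1cc2c(N3CCc4ccccc43)ncnc2cc1O[C@@H]1CCOC1` is made from compound 3 by piperidin-1-yl in place of ethyl on a saturated chain carbon bound to a double-bonded chain carbon. Among the measured compounds shown here, none of the measured steps touches this part of the chain; they only exchange one small alkenyl group for another, and every one of them is within the scatter. The expectation for compound 4 therefore rests mainly on the closeness of the three measured numbers, with no guide for the new group, so only a small step is estimated: a 2.1-fold lower number from compound 3 to compound 4 (0.31 log units; beyond the scatter). For compound 4 in this assay the estimated value is 4500 nM, expected to lie between 1200 nM and 15000 nM.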

Compound 4, half-maximal inhibitory concentration: 4510 nM
The estimate for compound 4 lay 1.0-fold (0.00 log units) below the measured number; measured number inside the range.
By their numbers in this assay, from the lowest: compounds 4, 2, 1 and 3 (each within the scatter of the next, the first and the last beyond it).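

Among the compounds shown here, putting piperidin-1-yl in place of ethyl on a saturated chain carbon bound to a double-bonded chain carbon gives a 2.0-fold lower number from compound 3 to compound 4 (0.31 log units; beyond the scatter) in this assay and is the first step in this set beyond the scatter, though only a modest one. This position therefore accepts a six-membered ring carrying a nitrogen without any loss of activity, since the steps to the smaller acyl groups stay within the scatter: a 1.0-fold lower number from compound 2 to compound 4 (0.01 log units; within the scatter) and a 1.1-fold lower number from compound 1 to compound 4 (0.04 log units; within the scatter). Nothing measured here bears on the reason for the step from ethyl to piperidin-1-yl.

As far as these compounds go, whether the ring or its nitrogen matters more stays open, as a cyclohexyl group or an open-chain dimethylamino group at this carbon would be needed to separate them. Morpholin-4-yl at the same place would show whether a second hetero atom in the ring changes the number.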